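Oxazole ketones: methylsulfanyl in place of pivaloyl

A few compounds are considered here, and "the series" means these few. Any claim that something is new, unique, unknown or untested is made for them only; others in the source may bear on it.

Three compounds sharing the aryl-alkyl ketone motif have been run in an assay on HEK-293T cells for inhibition of diacylglycerol lipase-alpha (Homo sapiens), read by colorimetric assay; on this read-out higher numbers stand for weaker inhibition and lower numbers for stronger inhibition. Compound 1 `O=C(CCCCCc1ccccc1)c1nc2cnccc2o1` gives 204 nM. Compound 2 `O=C(CCCCCCc1ccccc1)c1ncc(-c2ccco2)s1` gives only a limit of the assay, > 10000 nM; that limit is the limit of > 10000 nM in this assay, at which 1 of the 3 values shown sits. Compound 3 `CC(C)(C)C(=O)c1coc(C(=O)CCCCCCc2ccccc2)n1` gives 479 nM, the highest of the two numbers, with compound 1 as its nearest neighbour at a lower number beyond the usual scatter.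

Compound 4 `CSc1coc(C(=O)CCCCCCc2ccccc2)n1` has not yet been measured in this assay. It differs from compound 3 by methylsulfanyl in place of (tert-butyl)carbonyl on an aromatic carbon. For the measured compounds named here, no pair of measured compounds shows this change, so there is no step to lean on; compound 1 and compound 3 differ in several places at once and give no isolated read of the substituent on the five-membered ring.

Given the exchange of a carbonyl-bearing group for methylsulfanyl, compound 4 is expected to sit at a somewhat higher number than compound 3 in this assay, an estimated step of a 3.1-fold higher number from compound 3 to compound 4 (0.50 log units; beyond the scatter). The estimate for compound 4 is 1500 nM, with a range from 300 nM to 8000 nM, and a real chance that only a limit is returned.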

Compound 4, half-maximal inhibitory concentration: > 10000 nM
Compound 4: only a limit was reported; the forecaster's own chance of this, stated with the estimate: 15%; middle value at least 6.6-fold (0.82 log units) from the limit.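

Methylsulfanyl in place of (tert-butyl)carbonyl gives the first single-place read at this position, an aromatic carbon next to the ring nitrogen, and in this assay the change is large, with an at least 20-fold higher number from compound 3 to compound 4 (1.31 log units; beyond the scatter). Compound 4 returns only a limit of the assay, not a number, so this step has a floor but no measured size: the limit of > 10000 nM in this assay, at which 2 of the 4 values shown sit.

For the compounds shown here, the measurable inhibition of compound 3 is thus not kept by every group at this position, which the earlier compounds could not show. Going by these compounds, with only these two groups compared here, it remains open whether the carbonyl or the tert-butyl part of the (tert-butyl)carbonyl matters more. An acetyl group, a methyl ester or a plain tert-butyl group on the same carbon would separate the two.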